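Fluorine on the Outer Ring of Compound 1

This account rests on a few compounds, and the source may have more. Where it says the series, first, only, none or still open, it means among the compounds named here.

Measured compounds:
compound 1, `CC(C)C[C@H](N)CN(C(=O)[C@@H]1C[C@H]1c1ccccc1)c1ccc(-c2ccccc2)cc1`, 880 nM
compound 2, `CC(C)C[C@H](N)CN(C(=O)C(C)Cc1ccccc1)c1ccc(-c2ccccc2)cc1`, 1.2 nM

In a functional assay for agonist activity at G protein-coupled receptor 88 (Homo sapiens), read by HTRF and cAMP accumulation (on this read-out lower numbers stand for an effect already at smaller amounts and higher numbers for an effect only at larger amounts of compound), compound 1 gives the highest of the two numbers; its nearest neighbour is compound 2, which gives 1.2 nM, a step of a 730-fold lower number from compound 1 to compound 2 (2.87 log units; beyond the scatter) that arises from putting 1-benzylethyl in place of 2-phenylcyclopropyl on the carbonyl carbon.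

Compound 3, `CC(C)C[C@H](N)CN(C(=O)[C@@H]1C[C@H]1c1ccccc1)c1ccc(-c2ccc(F)cc2)cc1`, has not yet been measured. Compared with compound 1 it carries fluoro in place of hydrogen on an aromatic carbon, that is, phenyl becomes 4-fluorophenyl on the outer ring of the shared core. Going by the values given here, the one measured step concerns the group on the carbonyl carbon, not this ring, so no measured step bears on the change from compound 1 to compound 3. With nothing to guide a direction, the expected step is a 1.1-fold lower number from compound 1 to compound 3 (0.04 log units; within the scatter), none beyond the scatter. Compound 3 is therefore estimated at 800 nM, within a range of 300 nM to 2500 nM.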

Compound 3, half-maximal effective concentration: 900 nM
Compound 3: middle estimate off by 1.1-fold (0.05 log units), on the low side, and the stated range covers the measured number.
By their numbers in this assay, from the lowest: compound 2; then compounds 1 and 3 (each within the scatter of the next).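

In this assay, fluoro in place of hydrogen on an aromatic carbon, para to a large group, gives a 1.0-fold higher number from compound 1 to compound 3 (0.01 log units; within the scatter), so on the core of compound 1 this assay cannot tell phenyl from 4-fluorophenyl. Going by these compounds alone, the earlier step, a 730-fold lower number from compound 1 to compound 2 (2.87 log units; beyond the scatter), concerned only the group on the carbonyl carbon, whereas this result is the first reading from the outer ring, and the change here is far smaller than that step. Nothing measured here accounts for this result.

Going by these compounds, whether an amine, a carboxylic acid or a methoxy group at this same place would move the number remains open, as does fluoro elsewhere on the ring. Also open, on these data alone, is whether fluoro would leave the number just as unmoved on compound 2, which carries 1-benzylethyl on the carbonyl carbon.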